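Methyl on the Bridging Nitrogen, Amide Versus Amine

This account rests on a few compounds, and the source may have more. Where it says the series, first, only, none or still open, it means among the compounds named here.

Measured in an assay on isolated protein for inhibition of Amine oxidase [flavin-containing] A (Homo sapiens); on this read-out higher numbers stand for weaker inhibition and lower numbers for stronger inhibition:
compound 1, `Cn1c(C(=O)Nc2ccccc2)cc2ccccc21`, gives 100000000 nM
compound 2, `CN(C(=O)c1cc2ccccc2n1C)c1ccccc1`, gives 15000000 nM
compound 3, `Cn1c(CNc2ccccc2)cc2ccccc21`, gives 10000000 nM

Compounds 1 and 2 differ in one place: methyl in place of hydrogen on an amide-type nitrogen. That change gave a 6.7-fold lower number from compound 1 to compound 2 (0.82 log units; beyond the scatter). Compound 3 carries an amine bridge where compound 1 carries an amide; the difference between the two cores is not broken down here. The values of compound 3 and compound 2 lie within the scatter of each other, so nothing separates them.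

Compound 4, `CN(Cc1cc2ccccc2n1C)c1ccccc1`, has not yet been measured. It differs from compound 3 in one place: methyl in place of hydrogen on a nitrogen on an aromatic ring. For the measured compounds named here, this is the same kind of change as the one from compound 1 to compound 2, but the surroundings differ: in compound 1 the nitrogen is amide-type with aromatic carbon and carbonyl carbon as its other neighbours, whereas in compound 3 it has aromatic carbon and saturated chain carbon. Going by the values given here, with only one earlier example, the step is expected to be smaller than a 6.7-fold lower number from compound 1 to compound 2 (0.82 log units; beyond the scatter), roughly a 3.3-fold lower number from compound 3 to compound 4 (0.52 log units; beyond the scatter). Compound 4 is therefore estimated at 3000000 nM, likely between 500000 nM and 15000000 nM.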

Compound 4, inhibition constant: 6000000 nM
The estimate for compound 4 lay 2.0-fold (0.30 log units) below the measured number; low and high end bracket the measured number.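

On the core of compound 3, methyl in place of hydrogen on the nitrogen gives a 1.7-fold lower number from compound 3 to compound 4 (0.22 log units; within the scatter) in this assay, so here the change cannot be told apart from no change at all. The step therefore does not carry over at the same size from the amide-bridged compounds to the amine-bridged ones, and the gap between the two steps is larger than repeated measurements would explain: the same change on two cores in this assay, a 6.7-fold lower number (0.82 log units; beyond the scatter) from compound 1 to compound 2 and a 1.7-fold lower number (0.22 log units; within the scatter) from compound 3 to compound 4, 4.0-fold (0.60 log units) apart, beyond the scatter of two such steps

This shows that the size of the step depends on the core in these two pairs, but two pairs give no general rule for other cores, and the numbers do not show why the steps differ. Still open, on these data alone, is whether a longer chain on that nitrogen, such as ethyl or propyl, would also give different steps on the two cores. Also open, as far as these compounds go, is whether a carboxylic acid or a further amine added to either core would bring the numbers much lower.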